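Thiosemicarbazone series: nitro in place of hydroxy on the aryl ring

The compounds below may be only part of what the source reports. "The series", "measured", "known", "first", "only" and "open" are said of these compounds alone.

Measured so far:
compound 1 `CC1=CC[C@H](C(C)(C)NC(=S)N/N=C/c2ccccc2O)CC1` — 16600 nM
compound 2 `CC1=CC[C@H](C(C)(C)NC(=S)N/N=C/c2ccc(Cl)cc2)CC1` — 70500 nM

Both numbers come from a functional assay on HT-29 cells (Homo sapiens) for inhibition, read by sulforhodamine B assay, with a stated time of 48 h; on this read-out higher numbers stand for weaker inhibition of growth and lower numbers for stronger inhibition of growth. Compound 1 stands at the lowest of the two numbers; its nearest neighbour is compound 2, and the step of a 4.2-fold higher number from compound 1 to compound 2 (0.63 log units; beyond the scatter) lies beyond the scatter. Compound 3 `CC1=CC[C@H](C(C)(C)NC(=S)N/N=C/c2ccccc2[N+](=O)[O-])CC1` is not yet measured in this assay. It differs from compound 1 by nitro in place of hydroxy on an aromatic carbon. For the measured compounds named here, the only measured step that bears on this change is a 4.2-fold higher number from compound 1 to compound 2 (0.63 log units; beyond the scatter), which also removed the hydroxy from the aryl ring, put a different group onto that ring and weakened growth inhibition; it is not the same change, since the entering group and where it sits on the ring differ from compound 3. Going by the values given here, with this single step as the only guide, a move in the same direction as from compound 1 to compound 2 is expected, of a size somewhat below that step. The step from compound 1 to compound 3 is expected to be a 2.4-fold higher number from compound 1 to compound 3 (0.38 log units; beyond the scatter). For compound 3 the estimate in this assay is 40000 nM, within a range from 15000 nM to 110000 nM.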

Compound 3, concentration for total growth inhibition: 70800 nM
For compound 3 the middle estimate is 1.8-fold (0.25 log units) below the measured one; the measured number falls inside the stated range.
By their numbers in this assay, from the lowest: compound 1; then compounds 2 and 3 (each within the scatter of the next).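

In this assay, keeping the substituent on the same aromatic carbon, ortho to a large group, and exchanging only hydroxy for nitro gives a 4.3-fold higher number from compound 1 to compound 3 (0.63 log units; beyond the scatter), so growth inhibition weakens with a change at this single position. The earlier step to compound 2 altered both the group and its place on the ring, whereas this step shows that the loss of potency does not depend on moving the substituent: nitro at the original carbon is enough. Compound 1 now stands lowest, with its steps to compound 2 and compound 3 both beyond the scatter, but no measurement on hand accounts for the step.

From the compounds shown here alone, what an amine or a methoxy on that same aromatic carbon would give remains open, so it cannot yet be said whether hydroxy is unusual here or nitro is simply one of many groups that give a higher number. The compounds shown also leave open whether hydroxy at another ring carbon would retain the number of compound 1, and whether the step would hold in cells other than those of this single read-out.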